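A few compounds are considered here, and "the series" means these few. Any claim that something is new, unique, unknown or untested is made for them only; others in the source may bear on it.

In a functional assay on DU-145 cells (Homo sapiens) for cytotoxicity, read by MTT assay (a lower number here means a stronger inhibitor, a higher number a weaker inhibitor), compound 1 `CC(C)=CC[C@@H](OC[C@H](C)O)C1=CC(=O)c2c(O)ccc(O)c2C1=O` gives 24500 nM. Compound 2 `CCCC(O)CC(=O)O[C@H](CC=C(C)C)C1=CC(=O)c2c(O)ccc(O)c2C1=O` reads > 100000 nM, which is a limit and not a number, and it stands at the limit of > 100000 nM in this assay, at which 1 of the 2 values shown sits.

Compound 3 `COC(C)CO[C@H](CC=C(C)C)C1=CC(=O)c2c(O)ccc(O)c2C1=O` has 2-methoxypropyl in place of (2-hydroxypentyl)carbonyl on an oxygen on a saturated carbon.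

Among the compounds with values here, one measured step bears on this change, since it brought in the same (2-hydroxypentyl)carbonyl that now leaves. That step is an at least 4.0-fold higher number from compound 1 to compound 2 (0.61 log units; beyond the scatter). Its size is open-ended, so the reverse direction is better founded than any exact magnitude. Removing the group from compound 2 is therefore expected to give a lower number in this assay, beyond the scatter.

The expected change is an at least 4.0-fold lower number from compound 2 to compound 3 (0.60 log units; beyond the scatter). The estimated value for compound 3 is 25000 nM, with an expected range from 8000 nM to 80000 nM.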

Compound 3, half-maximal inhibitory concentration: 16600 nM
Beside the measured number, compound 3's estimate is 1.5-fold (0.18 log units) above it; the range from low to high includes it.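

Putting 2-methoxypropyl in place of (2-hydroxypentyl)carbonyl on this oxygen gives an at least 6.0-fold lower number from compound 2 to compound 3 (0.77 log units; beyond the scatter) in this assay, so a second group besides the 2-hydroxypropyl of compound 1 returns a measurable reading. Compound 2 remains a limit and not a number, so the size of that step is open-ended: the limit of > 100000 nM in this assay, at which 1 of the 3 values shown sits.

Exchanging the terminal hydroxyl side for methoxy, as 1-methoxyethyl in place of 1-hydroxyethyl, gives a 1.5-fold lower number from compound 1 to compound 3 (0.17 log units; within the scatter), so a free hydroxyl on this side chain is not required for activity at this level.

Compound 2 differs from the other two in both its carbonyl and its chain length, so the two features cannot be separated here. As far as these compounds go, whether a longer chain without the carbonyl, or an amine or carboxylic acid at the chain end, would keep this reading remains open.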